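Notes on the aryl series: compound 3 to compound 4

The source may hold more compounds than are shown below. What is called first, only, known or untested is meant among the compounds shown, and "the series" means these compounds.

Measured compounds:
compound 1 `Fc1ccccc1N1CCN(Cn2nc(-c3ccc4c(c3)OCCO4)oc2=S)CC1` — 37800 nM
compound 2 `S=c1oc(-c2ccc3c(c2)OCCO3)nn1CN1CCN(c2ccc(Cl)cc2)CC1` — > 50000 nM
compound 3 `S=c1oc(-c2ccc3c(c2)OCCO3)nn1CN1CCN(c2cccc(Cl)c2)CC1` — > 50000 nM

In a functional assay on SW 1116 cells (Homo sapiens) for antiproliferative activity, read by MTT assay, with a stated time of 48 h (a higher number here means a weaker inhibitor, a lower number a stronger inhibitor), compound 1 gives 37800 nM. For compound 2 the reading is a limit of the assay, > 50000 nM. For compound 3 the reading is likewise a limit, > 50000 nM. Compound 3 thus stands at the top of the numbers shown, together with compound 2, at the limit of > 50000 nM in this assay, at which 2 of the 3 values shown sit.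

The measured steps all concern the aryl group on the amine nitrogen in a ring: an at least 1.3-fold higher number from compound 1 to compound 2 (0.12 log units; that floor lies within the scatter) and an at least 1.3-fold higher number from compound 1 to compound 3 (0.12 log units; that floor lies within the scatter), and a step that the two limits leave unreadable from compound 2 to compound 3. None of them removes a halogen altogether, so they bear on the next step only loosely.

Compound 4 `S=c1oc(-c2ccc3c(c2)OCCO3)nn1CN1CCN(c2ccccc2)CC1` differs from compound 3 by hydrogen in place of chloro on an aromatic carbon. Since compound 3 gives only a limit, the step to compound 4 can be read only if compound 4 comes in below that limit. Within the data shown here, compound 1, the one compound with a number, carries a halogen as well and is itself weak, so no step here argues for a clear gain. Compound 4 is therefore expected to sit close to the limit, with the step of a number no higher from compound 3 to compound 4 (the limit leaves the size open) expected to be small or not readable. The estimate for compound 4 is 50000 nM, ranging from 20000 nM to 150000 nM.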

Compound 4, half-maximal inhibitory concentration: > 50000 nM
Compound 4: only a limit was reported (the forecaster's own chance of this, stated with the estimate: 60%); the middle value sits exactly at the limit.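

In this assay compound 4 gives > 50000 nM, which is a limit of the assay. With the chloro gone, the plain phenyl stays at the same limit as the 3-chlorophenyl and 4-chlorophenyl compounds, so the chloro is not required for a reading at this limit, and the steps among these three cannot be read: the limit of > 50000 nM in this assay, at which 3 of the 4 values shown sit.

Among these compounds, the only readable new step is an at least 1.3-fold higher number from compound 1 to compound 4 (0.12 log units; that floor lies within the scatter), and this floor does not establish that the 2-fluorophenyl of compound 1 differs from the plain phenyl.

As far as these compounds go, the true size of that difference stays open, as does any difference among compound 2, compound 3 and compound 4 beyond the reach of the assay. Also open, from the compounds shown here alone, is whether a group of another kind on the phenyl ring, such as a methoxy group, an amine or a carboxylic acid, would bring a reading well under the limit.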